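The source may report more compounds than this note shows. Statements on the series, on what has been measured and on what is new or still open speak of the compounds shown alone.

Compound 2 `O=[N+]([O-])c1cccc(NC(=S)NCCNS(=O)(=O)c2ccc(-c3ccccc3OCc3ccccc3)s2)c1` gives 12800 nM in a functional assay on HeLa cells (Homo sapiens) for inhibition, read by CCK-8 assay, with a stated time of 48 h (on this read-out lower numbers stand for stronger inhibition and higher numbers for weaker inhibition), the highest of the two numbers shown. Its nearest neighbour is compound 3 `O=[N+]([O-])c1ccc(NC(=S)NCCNS(=O)(=O)c2ccc(-c3ccccc3OCc3ccccc3)s2)cc1`, which in this assay gives 7100 nM, with the step of a 1.8-fold lower number from compound 2 to compound 3 (0.26 log units; within the scatter). Compound 1 `O=C(NCCNS(=O)(=O)c1ccc(-c2ccccc2OCc2ccccc2)s1)Nc1cc(Cl)cc(Cl)c1` yields only a limit in this assay, namely > 20000 nM (the limit of > 20000 nM in this assay, at which 1 of the 3 values shown sits). The steps from it are an at least 1.5-fold lower number from compound 1 to compound 2 (0.19 log units; that floor lies within the scatter) and an at least 2.8-fold lower number from compound 1 to compound 3 (0.44 log units; beyond the scatter). Compound 4 `O=[N+]([O-])c1cccc(NC(=S)NCCNS(=O)(=O)c2ccc(-c3ccccc3OCc3cccc(O)c3)s2)c1` differs from compound 2 by hydroxy in place of hydrogen on an aromatic carbon. For the measured compounds named here, every measured step concerns the group on the amide-type nitrogen; none touches the benzyloxy part, so no measured step bears on this change, and the expected step is none beyond the scatter, a 1.1-fold lower number from compound 2 to compound 4 (0.03 log units; within the scatter). Compound 4 is therefore estimated at 12000 nM, expected between 4500 nM and 30000 nM.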

Compound 4, half-maximal inhibitory concentration: 11100 nM
The estimate for compound 4 lay 1.1-fold (0.03 log units) above the measured number, within the range that was stated.
By their numbers in this assay, from the lowest: compounds 3, 4 and 2 (each within the scatter of the next). At a limit, above all of these: compound 1.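

Hydroxy in place of hydrogen on the benzyl ring, meta to a large group, is the first change shown outside the group on the amide-type nitrogen, and in this assay it gives a 1.2-fold lower number from compound 2 to compound 4 (0.06 log units; within the scatter). At this position, then, the added hydroxy produces no readable change in inhibition of HeLa cells. No measurement shown here bears on why this is so.

Going by these compounds, whether a methoxy group or an amine at this position would move the number beyond the scatter remains open. So does whether the 3-hydroxybenzyl group would behave alike alongside the 4-nitrophenyl group of compound 3.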